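This account rests on a few compounds, and the source may have more. Where it says the series, first, only, none or still open, it means among the compounds named here.

Working notes on the series. Two compounds carry numbers in a functional assay on Caco-2 cells (Homo sapiens) for inhibition, read by MTT assay, with a stated time of 48 h, tested at 10 uM; a lower number here means less inhibition of growth, a higher number more inhibition of growth at the concentration tested. Compound 1, `Cc1cc(=O)c2c(O)c(CN3CC(O)CC3C(=O)O)c(O)c([C@H]3CCN(C)C[C@H]3O)c2o1`, gives 19%. Compound 2, `Cc1oc2c([C@H]3CCN(C)C[C@H]3O)c(O)cc(O)c2c(=O)c1C(O)c1ccccc1Br`, gives 7%, the lower of the two numbers, and its gap to compound 1 lies beyond the usual scatter; on the numbers shown, compound 2 stands at the bottom.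

The next compound, compound 3, is `COc1ccc(C(O)c2c(C)oc3c([C@H]4CCN(C)C[C@H]4O)c(O)cc(O)c3c2=O)cc1Br`. Against compound 2 it differs in one place: 3-bromo-4-methoxyphenyl in place of 2-bromophenyl on a saturated chain carbon bound to an aromatic carbon and an oxygen on a saturated carbon. Among the compounds with values here, no measured pair shows a step of this kind, so nothing here says which way such a change moves growth inhibition, and the only anchor is the number of compound 2.

For compound 3 the step from compound 2 is expected to be small, a number 3 percentage points higher from compound 2 to compound 3 (within the scatter), and not beyond the scatter. Compound 3 is therefore estimated at 10%, with a range from 0% to 25%.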

Compound 3, percent growth inhibition at one concentration: 0%
Beside the measured number, compound 3's estimate is 10 percentage points above it; measured number inside the range.
By their numbers in this assay, from the lowest: compounds 3 and 2 (each within the scatter of the next); then compound 1.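

In this assay, the change to 3-bromo-4-methoxyphenyl in place of 2-bromophenyl on a saturated chain carbon bound to an aromatic carbon and an oxygen on a saturated carbon gives a number 7 percentage points lower from compound 2 to compound 3 (within the scatter) as the first step readable at this position. At this position, therefore, the exchange of these two bromine-bearing aryl groups, with the entering group carrying one hydrogen-bond acceptor and the leaving group none, does not shift growth inhibition beyond the scatter at the concentration tested. No measured evidence bears on why the step is this size.

A single step between two bromine-bearing aryl groups leaves open whether an amine, a carboxylic acid or a longer chain at this position would move growth inhibition beyond the scatter. Compound 1 differs from compound 2 and compound 3 in more than one place, so its steps to them cannot be read.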